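The source may hold more compounds than are shown below. What is called first, only, known or untested is meant among the compounds shown, and "the series" means these compounds.

In a functional assay on L1210 cells (Mus musculus) for inhibition (a lower number here means a stronger inhibitor, a higher number a weaker inhibitor), compound 1 `COC1=CC(=O)c2ncnc(NCCCN(C)C)c2C1=O` gives 0.501 ug/mL and stands level with compound 2 `CN(C)CCCNc1ncnc2c1C(=O)C(N1CCCCC1)=CC2=O` at 0.406 ug/mL and compound 3 `COC(=O)C(CC(C)C)NC(=O)C(CC(C)C)Nc1ncnc2c1C(=O)C(OC)=CC2=O` at 0.581 ug/mL within the scatter of repeated measurements. Compound 4 `CCN(CC)CCNc1ncnc2c1C(=O)C(OC)=CC2=O` differs from compound 1 (diethylamino in place of (dimethylamino)methyl on a saturated chain carbon, two bonds along the chain from a nitrogen on an aromatic ring) by diethylamino in place of (dimethylamino)methyl on a saturated chain carbon, two bonds along the chain from a nitrogen on an aromatic ring. Among the measured compounds shown here, the one measured step (a 1.2-fold lower number from compound 1 to compound 2 (0.09 log units; within the scatter)) is a different change, piperidin-1-yl in place of methoxy on a double-bonded ring carbon, and no measured step covers this chain. Compound 3 with a different chain still gives 0.581 ug/mL in this assay and so no step beyond the scatter is expected. The step expected is a 1.0-fold lower number from compound 1 to compound 4 (0.00 log units; within the scatter) and lies within the scatter. Compound 4 is estimated at 0.5 ug/mL (expected range 0.2 ug/mL to 1.2 ug/mL).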

Compound 4, half-maximal inhibitory concentration: 0.281 ug/mL
Compound 4: middle estimate off by 1.8-fold (0.25 log units), on the high side; the range from low to high includes it.
By their numbers in this assay, from the lowest: compounds 4, 2, 1 and 3 (each within the scatter of the next, the first and the last beyond it).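

In this assay, the saturated chain carbon two bonds along the chain from a nitrogen on an aromatic ring accepts diethylamino in place of (dimethylamino)methyl, with a 1.8-fold lower number from compound 1 to compound 4 (0.25 log units; within the scatter). Among the compounds shown here, this is the first single change read in the side chain, and it stays within the scatter, so the 3-(dimethylamino)propyl and 2-(diethylamino)ethyl chains cannot be told apart here. Nothing available bears on the reason for this result. Still open, as far as these compounds go, is whether a chain ending in a carboxylic acid or a hydroxyl group, or a longer chain carrying the same amine, would also stay within the scatter of compound 1.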